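The source may hold more compounds than are shown below. What is called first, only, known or untested is meant among the compounds shown, and "the series" means these compounds.

Series notes. The three measured compounds share one core and differ only on the saturated chain carbon bound to the oxygen on the aromatic ring. Compound 1 `COc1cc(CNc2nc3c(N)ncnc3n2[C@@H]2O[C@H](CO)[C@@H](O)[C@H]2O)ccc1-c1ccccc1` gives 1300 nM in an assay on COS-7 cells for inhibition of sodium/nucleoside cotransporter 2 (Homo sapiens), read by scintillation counting; on this read-out higher numbers stand for weaker inhibition and lower numbers for stronger inhibition. Compound 2 `CCOc1cc(CNc2nc3c(N)ncnc3n2[C@@H]2O[C@H](CO)[C@@H](O)[C@H]2O)ccc1-c1ccccc1` gives 2300 nM in this assay, and compound 3 `COC(=O)COc1cc(CNc2nc3c(N)ncnc3n2[C@@H]2O[C@H](CO)[C@@H](O)[C@H]2O)ccc1-c1ccccc1` gives 3300 nM. The number for compound 3 is the highest of the three; its gap to compound 2 lies within the scatter, its gap to compound 1 beyond it. The steps at this carbon were a 1.8-fold higher number from compound 1 to compound 2 (0.25 log units; within the scatter), a 2.5-fold higher number from compound 1 to compound 3 (0.40 log units; beyond the scatter) and a 1.4-fold higher number from compound 2 to compound 3 (0.16 log units; within the scatter). Compound 4 `Nc1ncnc2c1nc(NCc1ccc(-c3ccccc3)c(OCCCCO)c1)n2[C@@H]1O[C@H](CO)[C@@H](O)[C@H]1O` carries 3-hydroxypropyl in place of methoxycarbonyl on a saturated chain carbon bound to an oxygen on an aromatic ring. Because a 2.5-fold higher number from compound 1 to compound 3 (0.40 log units; beyond the scatter) and a 1.4-fold higher number from compound 2 to compound 3 (0.16 log units; within the scatter) were both modest, the next step at the same carbon is expected to be small as well, a 1.1-fold lower number from compound 3 to compound 4 (0.04 log units; within the scatter). Compound 4 is therefore estimated at 3000 nM, within 1200 nM to 7500 nM.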

Compound 4, half-maximal inhibitory concentration: 940 nM
Compound 4: the middle estimate sits 3.2-fold (0.50 log units) above what was measured; the whole stated range lies above it.
By their numbers in this assay, from the lowest: compounds 4, 1, 2 and 3 (each within the scatter of the next, the first and the last beyond it).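

In this assay 3-hydroxypropyl in place of methoxycarbonyl gives a 3.5-fold lower number from compound 3 to compound 4 (0.55 log units; beyond the scatter) and so shows that this carbon responds beyond the scatter to an exchange of groups of equal heavy-atom count. The same compound 4 gives a 2.4-fold lower number from compound 2 to compound 4 (0.39 log units; beyond the scatter) and also a 1.4-fold lower number from compound 1 to compound 4 (0.14 log units; within the scatter) and so shows that the 4-hydroxybutoxy chain does not carry the number upward in this small set. No evidence on hand bears on this result.

Whether the hydroxyl or the chain itself accounts for the step stays open. A plain butyl chain, or a chain ending in an amine or a carboxylic acid, would separate the two.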